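Demethylation of the ether tail on the amide nitrogen

A few compounds are considered here, and "the series" means these few. Any claim that something is new, unique, unknown or untested is made for them only; others in the source may bear on it.

The two measured compounds share one core. Compound 1 `COc1cccc2cc(C(=O)N[C@@H](CO)C(=O)O)c(=O)oc12` gives 3% in an assay on HeLa cells for displacement of a labelled ligand from adenosine receptor A3 (Homo sapiens), read by scintillation counting, with a stated time of 180 min, tested at 10 uM (a higher number here means more inhibition at the concentration tested (going by the name of the read-out), a lower number less inhibition), and compound 2 `COCCNC(=O)c1cc2cccc(OC)c2oc1=O` gives 0% in this assay. Compound 2 stands lowest of the two numbers shown, with compound 1 nearest, and the step of a number 3 percentage points lower from compound 1 to compound 2 (within the scatter) lies within the scatter. Compound 3 `COc1cccc2cc(C(=O)NCCO)c(=O)oc12` is not yet measured; it differs from compound 2 by hydrogen in place of methyl on an oxygen on a saturated carbon, the same difference read one bond further out as 2-methoxyethyl to 2-hydroxyethyl. Among the compounds with values here, no measured step repeats this change. Within the data shown here, the only step known, from a 1-carboxy-2-hydroxyethyl to a 2-methoxyethyl on the same amide-type nitrogen, stayed within the scatter, so a change at the far end of that chain is expected to give no step beyond the scatter either, a number 2 percentage points higher from compound 2 to compound 3 (within the scatter). Compound 3 is therefore estimated at 2% in this assay, with a range from -8% to 12%.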

Compound 3, a percentage reported as inhibition, at one concentration (the size of the read-out at that concentration, not a potency): 1%
Estimate against measurement, compound 3: 1 percentage points above; the range from low to high includes it.
By their numbers in this assay, from the lowest: compounds 2, 3 and 1 (each within the scatter of the next).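

In this assay, taking the methyl off the ether oxygen of the tail gives a step that stays within the scatter (a number 1 percentage points higher from compound 2 to compound 3 (within the scatter)), so methoxy and hydroxy at the end of this chain cannot be told apart here. Hydrogen in place of carboxy on the saturated chain carbon bound to the amide-type nitrogen, now seen as a change of its own, also stays within the scatter (a number 2 percentage points lower from compound 1 to compound 3 (within the scatter)). Nothing at hand offers an explanation for these readings.

From the compounds shown here alone, with all three compounds within the scatter of one another, it remains open whether any group on this amide-type nitrogen can lift the number in this assay. Going by these compounds, a terminal amine, a longer chain or a phenyl group in this place would each test that, and the methoxy on the shared core stays unexplored.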